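The compounds below may be only part of what the source reports. "The series", "measured", "known", "first", "only" and "open" are said of these compounds alone.

Among the measured compounds shown here, compound 1 (`O=S(=O)(O)OCCCCCCCCCCCC[Te]c1ccccc1`) gives 19800 nM in a functional assay on HCT-116 cells (Homo sapiens) for cytotoxicity, read by MTT assay, with a stated time of 24 h (on this read-out lower numbers stand for stronger inhibition and higher numbers for weaker inhibition), and is the only one of the measured compounds to return a number. Compound 2 (`O=S(=O)(O)OCCCCCCCCCCCC[Se]c1ccccc1`) gives > 100000 nM in this assay and this is a limit. Compound 3 (`O=S(=O)(O)OCCCCCCCCCCC[Se]c1ccccc1`) likewise gives > 100000 nM in this assay and this too is a limit. It therefore stands with compound 2 at the limit of > 100000 nM in this assay, at which 2 of the 3 values shown sit, and has no exact place on the scale.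

Compound 4 (`O=S(=O)(O)OCCCCCCCCCCC[Te]c1ccccc1`) differs from compound 3 in one place: a group of 7 heavy atoms (6 carbon, 1 tellurium; one six-membered aromatic ring of carbon only) in place of a group of 7 heavy atoms (6 carbon, 1 selenium; one six-membered aromatic ring of carbon only), on a saturated chain carbon, ten or more bonds along the chain from an oxygen with selenium giving way to tellurium. The closest measured parallel is an at least 5.0-fold higher number from compound 1 to compound 2 (0.70 log units; beyond the scatter) as the same exchange run in reverse. The pair an at least 5.0-fold higher number from compound 1 to compound 3 (0.70 log units; beyond the scatter) points the same way, while a step that the two limits leave unreadable from compound 2 to compound 3 shows that the chain difference cannot be sized among the selenium compounds. A lower number is therefore expected in this assay on moving to tellurium, by a step beyond the scatter, and the level is taken from compound 1 at 19800 nM in that assay. Compound 4 is expected at 20000 nM with an estimated range of 8000 nM to 50000 nM in this reading. This estimate amounts to an expected at least 5.0-fold lower number from compound 3 to compound 4 (0.69 log units; beyond the scatter) on the measured limit.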

Compound 4, half-maximal inhibitory concentration: 9730 nM
Compound 4: middle estimate off by 2.1-fold (0.31 log units), on the high side; the range from low to high includes it.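

In this assay, the exchange of selenium for tellurium on this saturated chain carbon now gives an at least 10-fold lower number from compound 3 to compound 4 (1.01 log units; beyond the scatter), so the drop seen on the longer chain recurs on the shorter one, and the second case can be set beside the first: the same change on two cores in this assay, an at least 5.0-fold higher number (0.70 log units; beyond the scatter) from compound 1 to compound 2 and an at least 10-fold higher number (1.01 log units; beyond the scatter) from compound 4 to compound 3; the limit leaves it open whether they differ The step of an at least 10-fold lower number from compound 2 to compound 4 (1.01 log units; beyond the scatter) changes the chain as well as the selenium atom, and it therefore adds no separate reading of the exchange, although it points the same way. The tellurium pair also gives the first readable size for the chain difference, with a 2.0-fold lower number from compound 1 to compound 4 (0.31 log units; beyond the scatter), a modest step beyond the scatter and in favour of the shorter chain.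

Going by these compounds, whether the same chain difference holds among the selenium compounds cannot be read, nor can the two exchange steps be ranked, because both selenium compounds stand at a limit: the limit of > 100000 nM in this assay, at which 2 of the 4 values shown sit. It also remains open whether a longer chain would reverse this chain step, or whether an amine or a carboxylic acid in place of sulfooxy would keep the level of the tellurium compounds.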